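One Ring Swap on a Carbamoyl Compound

The source may report more compounds than this note shows. Statements on the series, on what has been measured and on what is new or still open speak of the compounds shown alone.

In a functional assay (aorta) with Rattus norvegicus as the target, in the presence of a further agent that is not named here (on this read-out lower numbers stand for an effect already at smaller amounts and higher numbers for an effect only at larger amounts of compound), compound 1 (`COC(=O)C1=C(C)N=C(C)/C(=C(/O)OC)C1c1ccccc1OCc1nonc1C`) gives 41 nM, compound 2 (`COC(=O)C1=C(C)N=C(C)/C(=C(/O)OC)C1c1ccccc1OCc1c(C)no[n+]1[O-]`) gives 78 nM, and compound 3 (`COC(=O)C1=C(C)N=C(C)/C(=C(/O)OC)C1c1ccccc1OCc1nonc1C(N)=O`) gives 970 nM, the highest number of the three. Compound 4 (`COC(=O)C1=C(C)N=C(C)/C(=C(/O)OC)C1c1ccccc1OCc1c(C(N)=O)no[n+]1[O-]`) has not yet been measured. Its difference from compound 3 is a group of 9 heavy atoms (3 carbon, 3 nitrogen, 3 oxygen; one five-membered aromatic ring with 3 hetero atoms) in place of a group of 8 heavy atoms (3 carbon, 3 nitrogen, 2 oxygen; one five-membered aromatic ring with 3 hetero atoms), on a saturated chain carbon bound to an oxygen on an aromatic ring, so the 4-carbamoyl-1,2,5-oxadiazol-3-yl group leaves. The closest guide is the same kind of ring swap with methyl in place of carbamoyl, which gave a 1.9-fold higher number from compound 1 to compound 2 (0.28 log units; within the scatter). Two other steps were large, a 24-fold higher number from compound 1 to compound 3 (1.37 log units; beyond the scatter) and a 12-fold higher number from compound 2 to compound 3 (1.09 log units; beyond the scatter), but they report the arrival of carbamoyl, and that group is already present in compound 3 and compound 4. For the measured compounds named here, only one pair shows the ring swap, and none shows it with carbamoyl present, so the evidence is thin. No step beyond the scatter is therefore expected, and the estimated change is a 1.2-fold higher number from compound 3 to compound 4 (0.09 log units; within the scatter). For compound 4 the estimated value in this assay is 1200 nM, with an expected range from 400 nM to 3500 nM.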

Compound 4, half-maximal effective concentration: 560 nM
For compound 4 the middle estimate is 2.1-fold (0.33 log units) above the measured one; low and high end bracket the measured number.
By their numbers in this assay, from the lowest: compounds 1 and 2 (each within the scatter of the next); then compounds 4 and 3 (each within the scatter of the next).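

In this assay, the ring swap with carbamoyl present gives a 1.7-fold lower number from compound 3 to compound 4 (0.24 log units; within the scatter), so at this place, on a saturated chain carbon bound to an oxygen on an aromatic ring, the swap now stays within the scatter with carbamoyl as well as with methyl. Making both changes at once gives a 14-fold higher number from compound 1 to compound 4 (1.14 log units; beyond the scatter), and carbamoyl in place of methyl on the second ring gives a 7.2-fold higher number from compound 2 to compound 4 (0.86 log units; beyond the scatter), so carbamoyl raises the number on this ring too. The size of that rise differs between the two rings: the same change on two cores in this assay, a 24-fold higher number (1.37 log units; beyond the scatter) from compound 1 to compound 3 and a 7.2-fold higher number (0.86 log units; beyond the scatter) from compound 2 to compound 4, 3.3-fold (0.52 log units) apart, beyond the scatter of two such steps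

From the compounds shown here alone, only methyl and carbamoyl appear on these rings, so how an amine, a carboxylic acid or a longer chain would behave in their place stays open. Whether such groups would also differ in size between the two rings is equally unknown.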